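Chloro for Trifluoromethyl on Two Related Anilino Cores

The source may hold more compounds than are shown below. What is called first, only, known or untested is meant among the compounds shown, and "the series" means these compounds.

Compound 1 `O=S1(=O)C=Cc2ccc(Nc3ccc(C(F)(F)F)cc3)cc21` and compound 3 `O=S1(=O)C=Cc2cccc(Nc3ccc(C(F)(F)F)cc3)c21` are built from the same atoms joined differently; the difference between their two cores is not broken down here. In a functional assay on MCF7 cells (Homo sapiens) for antiproliferative activity, read by MTT assay, with a stated time of 72 h (a lower number here means a stronger inhibitor, a higher number a weaker inhibitor), compound 1 gives 1270 nM, and compound 3 gives 1820 nM, the two values lying within the usual scatter of each other. Compound 2 `O=S1(=O)C=Cc2ccc(Nc3ccc(Cl)cc3)cc21` differs from compound 1 by chloro in place of trifluoromethyl on an aromatic carbon, and in this assay compound 2 gives 2670 nM, which is a 2.1-fold higher number from compound 1 to compound 2 (0.32 log units; beyond the scatter). Compound 4 `O=S1(=O)C=Cc2cccc(Nc3ccc(Cl)cc3)c21` carries the same change relative to compound 3, namely (chloro in place of trifluoromethyl on an aromatic carbon), at the same place. The step from compound 3 to compound 4 in this assay is expected to be of similar size, a 2.1-fold higher number from compound 3 to compound 4 (0.32 log units; beyond the scatter). That expectation rests on compound 1, where the identical change gave a 2.1-fold higher number from compound 1 to compound 2 (0.32 log units; beyond the scatter). For compound 4 in this assay the estimated value is 3800 nM, most likely between 1500 nM and 9500 nM.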

Compound 4, half-maximal inhibitory concentration: 680 nM
Beside the measured number, compound 4's estimate is 5.6-fold (0.75 log units) above it; the whole stated range lies above it.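

On the core of compound 3, chloro in place of trifluoromethyl gives a 2.7-fold lower number from compound 3 to compound 4 (0.43 log units; beyond the scatter) in this assay. The same change therefore moved the number in opposite directions on the two cores, so its effect on one core could not be carried over to the other in this series: the same change on two cores in this assay, a 2.1-fold higher number (0.32 log units; beyond the scatter) from compound 1 to compound 2 and a 2.7-fold lower number (0.43 log units; beyond the scatter) from compound 3 to compound 4, 5.6-fold (0.75 log units) apart, beyond the scatter of two such steps

This rests on a single pair for each core, and it does not show what in the two cores sets the steps apart. The compounds shown leave open whether fluoro, methyl or methoxy in the same place would also behave differently on the two cores, and whether an amine or a carboxylic acid there would follow either step.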